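The source may hold more compounds than are shown below. What is called first, only, known or untested is meant among the compounds shown, and "the series" means these compounds.

Working notes on the series. Compound 1 `COc1ccccc1-n1c(SCC(=O)Nc2nc3ccc(C(F)(F)F)cc3s2)nc2c(c1=O)SCC2` and compound 3 `COc1ccccc1-n1c(SCC(=O)Nc2nc3ccc(C)cc3s2)nc2c(c1=O)SCC2` share one core; compound 2 `O=C(CNC(=O)c1nn(-c2ccc(F)cc2)c(=O)c2ccccc12)Nc1nc2ccc(C(F)(F)F)cc2s1` is built on another core, and the difference between the two cores is not broken down here. In an assay on L cells for inhibition of Protein-serine O-palmitoleoyltransferase porcupine (Mus musculus), read by reporter gene assay, with a stated time of 24 h (on this read-out higher numbers stand for an effect only at larger amounts of compound and lower numbers for an effect already at smaller amounts), compound 1 gives 30 nM, compound 3 gives 25 nM, and compound 2 gives 90 nM. Compound 2 has the highest number of the three; its nearest neighbour is compound 1 and the gap to compound 3 is somewhat wider, both gaps lying beyond the scatter.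

For the measured compounds named here, only one single-point change has been measured so far: from compound 1 to compound 3 the change is methyl in place of trifluoromethyl on an aromatic carbon, and in this assay it gave a 1.2-fold lower number from compound 1 to compound 3 (0.08 log units; within the scatter). Compound 4 `Cc1ccc2nc(NC(=O)CNC(=O)c3nn(-c4ccc(F)cc4)c(=O)c4ccccc34)sc2c1` carries the same change on the core of compound 2: methyl in place of trifluoromethyl on an aromatic carbon. The surroundings of the place are described in the same words for both pairs, so the change is taken as the same one, now made on the other core. Among the compounds shown it occurs twice in all, once measured and once not.

For compound 4 the expected step is a 1.2-fold lower number from compound 2 to compound 4 (0.08 log units; within the scatter), a flat move that rests on compound 1 turning into compound 3 with a 1.2-fold lower number from compound 1 to compound 3 (0.08 log units; within the scatter). Compound 4 is therefore estimated at 75 nM in this assay. Going by the values given here, the range for compound 4 is expected to run from 35 nM to 160 nM, widened because the precedent stands on the single pair with a 1.2-fold lower number from compound 1 to compound 3 (0.08 log units; within the scatter) and the core is different.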

Compound 4, half-maximal effective concentration: 100 nM
Beside the measured number, compound 4's estimate is 1.3-fold (0.12 log units) below it; the measured number falls inside the stated range.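

In this assay, methyl in place of trifluoromethyl on an aromatic carbon of the core of compound 2 gave a 1.1-fold higher number from compound 2 to compound 4 (0.05 log units; within the scatter), so the change is a flat move on this core, as it was on the core of compound 1. Set side by side, the two steps do not separate: the same change on two cores in this assay, a 1.2-fold lower number (0.08 log units; within the scatter) from compound 1 to compound 3 and a 1.1-fold higher number (0.05 log units; within the scatter) from compound 2 to compound 4, 1.3-fold (0.12 log units) apart, within the scatter of two such steps. For the compounds shown here, this shows that, in this series, the change carried from one core to the other without a step that can be told from the scatter, but it rests on only two pairs, one place and one assay; it does not show that the change would stay flat on any further core, and it gives no reason for the flat steps.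

Trifluoromethyl and methyl are the only groups shown at this place, so it remains open whether a chlorine, a nitrile, an amine, a carboxylic acid or a longer chain there would give a step beyond the scatter, and whether such a step would carry between the two cores. The difference between the two cores also stays unresolved, since no pair shown links them through a single change, and which of their parts bears on the read-out cannot be said.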